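The source may hold more compounds than are shown below. What is called first, only, known or untested is meant among the compounds shown, and "the series" means these compounds.

Working notes on the series. In a toxicity assay on MT4 cells (Homo sapiens) for cytotoxicity, read by MTT assay, with a stated time of 5 days (on this read-out higher numbers stand for lower toxicity in this test and lower numbers for higher toxicity in this test), compound 1 `Cc1ccc(-c2cc(C)c(Nc3ccnc(Nc4ccc(C#N)cc4)n3)c(C)c2)s1` gives 28000 nM and compound 2 `Cc1cc(-c2cc(F)nc(F)c2)cc(C)c1Nc1ccnc(Nc2ccc(C#N)cc2)n1` gives 6300 nM, the lower of the two numbers, so compound 2 is the more toxic of the pair in this test. Next is compound 3 `Cc1ncc(-c2cc(C)c(Nc3ccnc(Nc4ccc(C#N)cc4)n3)c(C)c2)cn1`, which differs from compound 2 as follows: 2-methylpyrimidin-5-yl in place of 2,6-difluoropyridin-4-yl on an aromatic carbon. The change is 2-methylpyrimidin-5-yl in place of 2,6-difluoropyridin-4-yl on an aromatic carbon. Among the compounds with values here, only one measured step bears on it, the exchange at that same carbon, a 4.4-fold lower number from compound 1 to compound 2 (0.65 log units; beyond the scatter), which is modest and beyond the scatter. Within the data shown here, with no measured compound carrying 2-methylpyrimidin-5-yl, that step is the only guide to size. In this assay, a modest upward move is expected, with the estimated step being a 2.2-fold higher number from compound 2 to compound 3 (0.35 log units; beyond the scatter). The expected value for compound 3 is 14000 nM, with an estimated range of 5000 nM to 45000 nM.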

Compound 3, half-maximal cytotoxic concentration: 3900 nM
Beside the measured number, compound 3's estimate is 3.6-fold (0.56 log units) above it, outside the stated range (below it).
By their numbers in this assay, from the lowest: compounds 3 and 2 (each within the scatter of the next); then compound 1.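

In this assay, a 1.6-fold lower number from compound 2 to compound 3 (0.21 log units; within the scatter) lies within the scatter, so at this aromatic carbon 2-methylpyrimidin-5-yl and 2,6-difluoropyridin-4-yl cannot be told apart, although the second carries two fluorines and the first a methyl group and a second ring nitrogen. With a 7.2-fold lower number from compound 1 to compound 3 (0.86 log units; beyond the scatter) beyond the scatter and in the same direction as a 4.4-fold lower number from compound 1 to compound 2 (0.65 log units; beyond the scatter), both six-membered aromatic rings now separate from 5-methylthiophen-2-yl, leaving compound 1 as the least toxic of the three in this test. No measurement shown gives a reason for this pattern.

From the compounds shown here alone, it remains open whether the higher number of compound 1 goes with the thiophene ring or with its methyl group. Going by these compounds, how a saturated amine such as morpholine or a carboxylic acid would read at this carbon in this assay also remains open.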